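This account rests on a few compounds, and the source may have more. Where it says the series, first, only, none or still open, it means among the compounds named here.

In a functional assay on MDA-MB-231 cells (Homo sapiens) for antiproliferative activity, read by luminescence, with a stated time of 24 h (on this read-out higher numbers stand for weaker inhibition and lower numbers for stronger inhibition), compound 1 `Cc1c(C)c2c(c(C)c1OC(=O)CCC(=O)O)CCC(C)(COc1ccc(CC3SC(=O)NC3=O)cc1)O2` gives > 25000 nM, a limit of the assay. Compound 2 `Cc1c(C)c2c(c(C)c1OC(=O)CCC(=O)O)CCC(C)(COc1ccc(/C=C3\SC(=O)NC3=O)cc1)O2` gives > 25000 nM, also a limit. Compound 2 therefore stands at the limit of > 25000 nM in this assay, at which 2 of the 3 values shown sit, and the pair shows a step that the two limits leave unreadable from compound 1 to compound 2. Compound 3 `Cc1c(C)c2c(c(C)c1OC(=O)OC(C)(C)C)CCC(C)(COc1ccc(CC3SC(=O)NC3=O)cc1)O2` gives a measured 3800 nM.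

Compound 4 `Cc1c(C)c2c(c(C)c1OC(=O)CCCCCCCN)CCC(C)(COc1ccc(/C=C3\SC(=O)NC3=O)cc1)O2` differs from compound 2 by 5-aminopentyl in place of carboxy on a saturated chain carbon, two bonds along the chain from a carbonyl carbon. Within the data shown here, the only readable step that bears on this change is an at least 6.5-fold lower number from compound 1 to compound 3 (0.81 log units; beyond the scatter), in which tert-butoxy replaces 2-carboxyethyl on a carbonyl carbon. That step also removes the carboxy group, but it brings in a different group and starts from compound 1, so its transfer to compound 2 is uncertain. A step of similar size towards a lower number is still expected in this assay. The expected move is an at least 6.2-fold lower number from compound 2 to compound 4 (0.79 log units; beyond the scatter). For compound 4 the estimate is 4000 nM, with an expected range of 1000 nM to 20000 nM.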

Compound 4, half-maximal inhibitory concentration: 5000 nM
Beside the measured number, compound 4's estimate is 1.3-fold (0.10 log units) below it, within the range that was stated.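

Among these compounds, exchanging carboxy for 5-aminopentyl, on a saturated chain carbon two bonds along the chain from a carbonyl carbon, gives an at least 5.0-fold lower number from compound 2 to compound 4 (0.69 log units; beyond the scatter) and so yields the first measured number on the core of compound 2. Among the compounds shown here, until now the only readable step at this position started from compound 1 and brought in tert-butoxy; compound 4 shows that a measured number also arises with a group that keeps a chain and ends in an amine. The starting point of this step is a limit of the assay: the limit of > 25000 nM in this assay, at which 2 of the 4 values shown sit.

As far as these compounds go, how much of the step comes from losing the carboxylic acid and how much from gaining the amine stays open; a plain alkyl chain of the same length would separate the two. From the compounds shown here alone, whether 5-aminopentyl gives a similar step on the core of compound 1 also stays open.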